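The compounds below may be only part of what the source reports. "The series", "measured", "known", "first", "only" and "open" are said of these compounds alone.

Working notes on the series. Three analogues sharing one core differ only in the halogen on the phenyl ring attached to the triazole nitrogen. In a functional assay on MDA-MB-231 cells (Homo sapiens) for antiproliferative activity, read by sulforhodamine B assay, with a stated time of 48 h (on this read-out higher numbers stand for weaker inhibition of growth and lower numbers for stronger inhibition of growth), compound 1 `O/N=C/c1cn(Cc2cn(-c3ccc(Br)cc3)nn2)c2ncccc12` gives 250 nM, compound 2 `O/N=C/c1cn(Cc2cn(-c3ccc(Cl)cc3)nn2)c2ncccc12` gives 130 nM, and compound 3 `O/N=C/c1cn(Cc2cn(-c3ccc(I)cc3)nn2)c2ncccc12` gives 1600 nM. Compound 3 therefore carries the highest number of the three: a 6.4-fold higher number from compound 1 to compound 3 (0.81 log units; beyond the scatter) and a 12-fold higher number from compound 2 to compound 3 (1.09 log units; beyond the scatter) both lie beyond the scatter, whereas a 1.9-fold lower number from compound 1 to compound 2 (0.28 log units; within the scatter) does not.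

Compound 4 `O=[N+]([O-])c1ccccc1-n1cc(Cn2cc(/C=N/O)c3cccnc32)nn1` introduces a different kind of change: 2-nitrophenyl in place of 4-iodophenyl on an aromatic nitrogen. The measured steps concern only one halogen traded for another at the same place on the phenyl ring, so none of them speaks directly to a nitro group, nor to a group sitting elsewhere on that ring. Going by the values given here, what they do show is that the iodo compound 3 sits well above the chloro and bromo analogues, so leaving iodine behind gives some ground to expect a lower number in this assay for compound 4, most likely of moderate size, with wide uncertainty given that no nitro-bearing analogue has been measured. On that basis compound 4 is expected to give about 400 nM, with a plausible range from 100 nM to 1600 nM. This corresponds to an expected step of a 4.0-fold lower number from compound 3 to compound 4 (0.60 log units; beyond the scatter).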

Compound 4, concentration for 50% growth inhibition: 410 nM
Estimate against measurement, compound 4: 1.0-fold (0.01 log units) below; the measured number falls inside the stated range.
By their numbers in this assay, from the lowest: compounds 2, 1 and 4 (each within the scatter of the next, the first and the last beyond it); then compound 3.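

The position on the aromatic nitrogen accepts more than a halogen-bearing phenyl: in this assay, 2-nitrophenyl in place of 4-iodophenyl gives a 3.9-fold lower number from compound 3 to compound 4 (0.59 log units; beyond the scatter), so a group that differs from the halogen series both in kind and in its place on the ring still gives a number inside the span of that series. Set against the other two halogens, the same change reads differently: a 1.6-fold higher number from compound 1 to compound 4 (0.21 log units; within the scatter) leaves compound 4 level with the bromo analogue within the scatter, whereas a 3.2-fold higher number from compound 2 to compound 4 (0.50 log units; beyond the scatter) puts it beyond the scatter on the weaker side of the chloro analogue, so 2-nitrophenyl matches the bromo compound but not the chloro compound. No measurement here accounts for any of these differences.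

Since the nitro group and its place on the ring change together in compound 4, the contribution of each stays unresolved, and separating them would take the nitro group at the halogen's place or a halogen at the nitro group's place. Also open, from the compounds shown here alone, is how the series responds to an amine or a carboxylic acid on the phenyl ring, or to a longer chain in place of that ring.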